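This account rests on a few compounds, and the source may have more. Where it says the series, first, only, none or still open, it means among the compounds named here.

Of the compounds shown here, three sharing one core have been tested in an ADME assay on Vero cells (Chlorocebus sabaeus) for cytotoxicity, read by resazurin assay, with a stated time of 3 days; on this read-out higher numbers stand for weaker inhibition and lower numbers for stronger inhibition. Compound 1, `CCN(CC)c1cc2[nH]c(C3CCCCC3)nc2cc1NC(=O)c1ccc(OC(F)(F)F)cc1`, carries a 4-(trifluoromethoxy)phenyl on the carbonyl carbon, and in this assay compound 1 gives > 100 ug/mL, which is a limit of the assay and not a number. Compound 2, `CCCCOC(=O)Nc1cc2nc(C3CCCCC3)[nH]c2cc1N(CC)CC`, carries a butoxy group on that carbon; compound 2 gives > 100 ug/mL, again a limit. Compound 3, `CCCC(C)OC(=O)Nc1cc2nc(C3CCCCC3)[nH]c2cc1N(CC)CC`, carries a 1-methylbutoxy group; compound 3 gives > 100 ug/mL, once more a limit. Compound 3 therefore stands at the limit alongside the other two, and the steps between them are unreadable: a step that the two limits leave unreadable from compound 1 to compound 2, a step that the two limits leave unreadable from compound 1 to compound 3 and a step that the two limits leave unreadable from compound 2 to compound 3, because of the limit of > 100 ug/mL in this assay, at which 3 of the 3 values shown sit.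

Compound 4, `CCN(CC)c1cc2[nH]c(C3CCCCC3)nc2cc1NC(=O)c1ccc(Br)cc1`, differs from compound 3 in that (4-bromophenyl in place of 1-methylbutoxy on a carbonyl carbon). The step from compound 1 to compound 3 exchanged an aromatic ring for an alkoxy group at this same carbonyl carbon and showed a step that the two limits leave unreadable from compound 1 to compound 3, with the aryl-bearing compound 1 also sitting at the limit. With no readable step available, the expectation for compound 4 is that it too stays at or near the limit, so the expected step is a step that the limit leaves unreadable from compound 3 to compound 4. The estimate for compound 4 is 120 ug/mL, expected to lie between 50 ug/mL and 300 ug/mL.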

Compound 4, half-maximal inhibitory concentration: > 100 ug/mL
Compound 4: only a limit was reported; the forecaster's own chance of this, stated with the estimate: 75%; the middle value lies beyond the limit too.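

In this assay compound 4 gives > 100 ug/mL, which is a limit of the assay and not a number. For the compounds shown here, no step between compound 4 and compound 1, compound 2 or compound 3 can be read, because all four compounds sit at the same limit: the limit of > 100 ug/mL in this assay, at which 4 of the 4 values shown sit. The compounds shown leave open at what concentration any of them would inhibit these cells, and whether the group on the carbonyl carbon changes that concentration.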